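The compounds below may be only part of what the source reports. "The series", "measured", "known", "first", "only" and "open" are said of these compounds alone.

Three compounds sharing one core have been run in a functional assay on MDA-MB-231 cells (Homo sapiens) for inhibition, read by sulforhodamine B assay, tested at 10 uM; a lower number here means less inhibition, a higher number more inhibition at the concentration tested (going by the name of the read-out). Compound 1 `CN(C)c1ccc(C2CC(c3ccc(-n4cncn4)cc3)=NN2C(=O)c2ccc(C(F)(F)F)cc2)cc1` gives 16.7%, compound 2 `CN(C)c1ccc(C2CC(c3ccc(-n4ccnc4)cc3)=NN2C(=O)CCCl)cc1` gives 2.1%, and compound 3 `C=C(C)C(=O)N1N=C(c2ccc(-n3ccnc3)cc2)CC1c1ccc(N(C)C)cc1` gives 4.3%. Compound 3 therefore stands second of the three: the nearer step is a number 2.2 percentage points higher from compound 2 to compound 3 (within the scatter), while the value of compound 1 lies higher by a gap beyond the scatter. Compound 4 `CN(C)c1ccc(C2CC(c3ccc(-n4ccnc4)cc3)=NN2C(=O)c2ccc(C(F)(F)F)cc2)cc1` differs from compound 3 by 4-(trifluoromethyl)phenyl in place of 1-methylethenyl on a carbonyl carbon. Going by the values given here, the only measured step at this carbonyl carbon is a number 2.2 percentage points higher from compound 2 to compound 3 (within the scatter), within the scatter, so it gives little guidance. Compound 1 carries the same entering group and gives 16.7%, yet it also differs from compound 4 elsewhere. Compound 4 is accordingly expected to reach 12%, with a range from 0% to 25%. The estimated step is a number 7.7 percentage points higher from compound 3 to compound 4 (within the scatter).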

Compound 4, a percentage reported as inhibition, at one concentration (the size of the read-out at that concentration, not a potency): 17.9%
Beside the measured number, compound 4's estimate is 5.9 percentage points below it; low and high end bracket the measured number.
By their numbers in this assay, from the lowest: compounds 2 and 3 (each within the scatter of the next); then compounds 1 and 4 (each within the scatter of the next).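

Going by these compounds alone, at the carbonyl carbon, 4-(trifluoromethyl)phenyl gives the first modest steps beyond the scatter in this assay for this position (a number 13.6 percentage points higher from compound 3 to compound 4 (beyond the scatter); a number 15.8 percentage points higher from compound 2 to compound 4 (beyond the scatter)). With that group in place, 1H-imidazol-1-yl in place of 1H-1,2,4-triazol-1-yl on an aromatic carbon stays within the scatter (a number 1.2 percentage points higher from compound 1 to compound 4 (within the scatter)). Nothing available explains the rise at the carbonyl carbon.

Whether the aromatic ring alone carries this rise remains open, since plain phenyl is not among the compounds shown. So does the outcome with a methoxy group or a fluorine atom in place of trifluoromethyl.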